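Methyl to Chloro on a Benzyl Group

This account rests on a few compounds, and the source may have more. Where it says the series, first, only, none or still open, it means among the compounds named here.

In an ADME assay on THP-1 cells (Homo sapiens) for cytotoxicity, read by trypan blue exclusion, with a stated time of 48 h (on this read-out lower numbers stand for stronger inhibition of growth and higher numbers for weaker inhibition of growth), compound 3 (`Cc1ccc(CNCc2cc(C)n(-c3ccc(Cl)cc3)c2C)cc1`) gives 6.1 ug/mL as the lowest of three numbers. Compound 1 (`Cc1c(CNCc2ccccc2)cc(-c2ccc(Cl)cc2)n1-c1ccc(Cl)cc1`) gives 99 ug/mL and compound 2 (`Cc1cc(/C=N\OCc2ccccc2)c(C)n1-c1ccc(Cl)cc1`) gives 500 ug/mL and both lie higher by more than the usual scatter. Compound 4 (`Cc1cc(CNCc2ccc(Cl)cc2)c(C)n1-c1ccc(Cl)cc1`) has not yet been measured. It differs from compound 3 in one place, with chloro in place of methyl on an aromatic carbon, so 4-methylbenzyl becomes 4-chlorobenzyl. Among the compounds with values here, no measured pair shows this change, so the expectation rests on the value of compound 3 (6.1 ug/mL). A step of a 1.3-fold higher number from compound 3 to compound 4 (0.12 log units; within the scatter) is expected in this assay towards a slightly higher number, not beyond the scatter. For compound 4 the estimate is 8 ug/mL with an expected range (2.5 ug/mL to 30 ug/mL).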

Compound 4, concentration for 50% growth inhibition: 18 ug/mL
The estimate for compound 4 lay 2.3-fold (0.35 log units) below the measured number; measured number inside the range.
By their numbers in this assay, from the lowest: compound 3; then compound 4; then compound 1; then compound 2.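

Within the data shown here, changing methyl to chloro gives a 3.0-fold higher number from compound 3 to compound 4 (0.47 log units; beyond the scatter) in this assay and so offers the first direct comparison at this position. It shows that this one atom on the benzyl ring can move the number beyond the usual scatter, with the methyl compound giving the lower number. Nothing measured here explains the step. On these data alone, whether a fluoro or methoxy group on that carbon would give a number nearer compound 3 or compound 4 remains open, as does whether this change would give a similar step on another core.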